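A few compounds are considered here, and "the series" means these few. Any claim that something is new, unique, unknown or untested is made for them only; others in the source may bear on it.

In a functional assay on BEL-7404 cells for cytotoxicity against BEL-7404 tumor cell line (Homo sapiens), read by MTT assay, with a stated time of 48 h (a higher number here means a weaker inhibitor, a lower number a stronger inhibitor), compound 1, whose structure is `Cc1ccc2[nH]c(=O)c(-c3nc4cc([N+](=O)[O-])ccc4[nH]3)cc2c1`, gives > 100000 nM, which is a limit of the assay rather than a measured number. Compound 2, `O=c1[nH]c2ccccc2cc1-c1nc2cc([N+](=O)[O-])ccc2[nH]1`, gives > 100000 nM in this assay, also a limit. Compound 3, `Cc1ccc2[nH]c(=O)c(-c3nc4cc(C)c(C)cc4[nH]3)cc2c1`, gives > 100000 nM in this assay, again a limit. So (the limit of > 100000 nM in this assay, at which 3 of the 3 values shown sit), and compound 1 stands there together with the other two, without any measured figure to place it higher or lower. The step that the two limits leave unreadable from compound 1 to compound 2 cannot be read; both of its ends are limits.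

The compound not yet measured, compound 4, has the structure `Cc1ccc2[nH]c(=O)c(-c3nc4cc(Cl)ccc4[nH]3)cc2c1`. It differs from compound 1 by chloro in place of nitro on an aromatic carbon. For the measured compounds named here, none of the measured steps concerns this exchange, and the only recorded step, a step that the two limits leave unreadable from compound 1 to compound 2, is unreadable in any case. Going by the values given here, with no measured step to lean on and every measured value sitting at the limit, the estimated step of a number no higher from compound 1 to compound 4 (the limit leaves the size open) is expected to be none beyond the scatter. Compound 4 is therefore estimated at 100000 nM, within a range from 30000 nM to 300000 nM, and it is expected that this assay will most likely again report only a limit for it.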

Compound 4, half-maximal inhibitory concentration: 39000 nM
Compound 4: the middle estimate sits 2.6-fold (0.41 log units) above what was measured; measured number inside the range.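

In this assay, chloro in place of nitro on this aromatic carbon produces the only readable change among the compounds shown: an at least 2.5-fold lower number from compound 1 to compound 4 (0.40 log units; beyond the scatter), a shift beyond the scatter toward a stronger inhibitor. From the compounds shown here alone, the result for compound 1 is a limit, so this step gives only a minimum size and the full size of the change remains unknown. It does show that the group at this place on the six-membered aromatic ring can move the result, and compound 4 now stands apart from the others as the only one with a measured number: the limit of > 100000 nM in this assay, at which 3 of the 4 values shown sit.

A single exchange cannot show whether chloro is unusual here or whether other groups at this place, such as an amine, a methoxy group or fluoro, would give a similar or larger shift. The effect of hydrogen in place of methyl also remains open, since its step from compound 1 to compound 2 cannot be read and no matching pair carrying chloro is shown.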